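A few compounds are considered here, and "the series" means these few. Any claim that something is new, unique, unknown or untested is made for them only; others in the source may bear on it.

Measured so far in an assay for inhibition of beta-glucuronidase (Bos taurus), read by spectrophotometry, with a stated time of 30 min; on this read-out higher numbers stand for weaker inhibition and lower numbers for stronger inhibition:
- compound 1, `O=[N+]([O-])c1ccccc1S(=O)(=O)Nc1cnc2ccccc2c1`: 8100 nM
- compound 2, `O=S(=O)(Nc1cnc2ccccc2c1)c1ccccc1`: 53400 nM
- compound 3, `O=S(=O)(Oc1cccc2cccnc12)c1ccccc1`: 49500 nM

Compound 2 and compound 3 share no counted difference; how their two cores differ is not broken down here. Within the core of compound 2, adding a nitro group nitro in place of hydrogen on an aromatic carbon gave a 6.6-fold lower number from compound 2 to compound 1 (0.82 log units; beyond the scatter) in this assay. Compound 4, `O=[N+]([O-])c1ccc(S(=O)(=O)Oc2cccc3cccnc23)cc1`, carries the same kind of change on the core of compound 3 (nitro in place of hydrogen on an aromatic carbon), but the place differs: para to a large group rather than ortho to a large group. Among the compounds with values here, since the only measured example of a nitro entering is the ortho case, the step is expected to be somewhat smaller: compound 4 is estimated to show a 3.3-fold lower number from compound 3 to compound 4 (0.52 log units; beyond the scatter) in this assay. Compound 4 is therefore expected to give about 15000 nM, likely between 4000 nM and 50000 nM.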

Compound 4, half-maximal inhibitory concentration: 15400 nM
The estimate for compound 4 lay 1.0-fold (0.01 log units) below the measured number; the measured number falls inside the stated range.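

In this assay, nitro in place of hydrogen on an aromatic carbon again lowered the number, giving a 3.2-fold lower number from compound 3 to compound 4 (0.51 log units; beyond the scatter), so the change carried over to a second core in the same direction. Set side by side, the two steps do not differ by more than the usual scatter: the same change on two cores in this assay, a 6.6-fold lower number (0.82 log units; beyond the scatter) from compound 2 to compound 1 and a 3.2-fold lower number (0.51 log units; beyond the scatter) from compound 3 to compound 4, 2.1-fold (0.31 log units) apart, within the scatter of two such steps. Two pairs are few, however, and they differ in both core and the place of the nitro, so the effects of core and place cannot be separated, and no rule for other cores follows.

Going by these compounds, it remains open whether an amine or a carboxylic acid in place of the nitro would lower the number as well. On these data alone, it is also open how the step would change if the nitro sat elsewhere on either core.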